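Trifluoromethoxy in place of methoxy on a shared oxime ether core

The source may hold more compounds than are shown below. What is called first, only, known or untested is meant among the compounds shown, and "the series" means these compounds.

Of the compounds shown here, two built on the same core have been tested in a functional assay on SMMC-7721 cells (Homo sapiens) for inhibition, read by MTT assay, with a stated time of 72 h, tested at 25 uM; on this read-out lower numbers stand for less inhibition and higher numbers for more inhibition at the one concentration tested (going by the name of the read-out). Compound 1 `Cc1nn(C)c(Oc2ccc(OC(F)(F)F)cc2)c1/C=N\OCc1c(Cl)c(-c2ccc(F)cc2)nn1C` carries a trifluoromethoxy group on its outer aromatic ring, and in this assay compound 1 gives 80%. Compound 2 `CCc1nn(C)c(CO/N=C\c2c(C)nn(C)c2Oc2ccc(OC)cc2)c1Cl` instead carries a methoxy group there, and in this assay compound 2 is reported only as a limit of the assay, < 80%, so its exact inhibition is not known; this is the limit described in the limit of < 80% in this assay, at which 1 of the 2 values shown sits. Among the measured compounds shown here, no pair of measured compounds differs in just one place, so no measured step is available.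

Compound 3 `CCc1nn(C)c(CO/N=C\c2c(C)nn(C)c2Oc2ccc(OC(F)(F)F)cc2)c1Cl` is the next compound, not yet measured in this assay. It differs from compound 2 by trifluoromethyl in place of methyl on an oxygen on an aromatic ring. Since compound 2 is known only as a limit, the size of the step to compound 3 can only be guessed, and a modest rise in this assay is expected, a step that the limit leaves unreadable from compound 2 to compound 3. On that basis compound 3 is expected to give about 60% in this assay, within a range from 25% to 85%.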

Compound 3, a percentage reported as inhibition, at one concentration (the size of the read-out at that concentration, not a potency): < 80%
Compound 3 was reported as a limit; the forecaster's own chance of this, stated with the estimate: 40%; the middle value does not contradict the limit.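

Compound 3 is also reported only as a limit in this assay, so trifluoromethoxy in place of methoxy on the outer aromatic ring does not yield a measured number, and the step between compound 2 and compound 3 cannot be read. Compound 1 and compound 3 share the trifluoromethoxy group and differ in one place, ethyl in place of 4-fluorophenyl on an aromatic carbon. That change gives a number no higher from compound 1 to compound 3 (the limit leaves the size open) and so having trifluoromethoxy is not enough on its own to give a value that is more than a limit. The limit now accounts for most of the data: the limit of < 80% in this assay, at which 2 of the 3 values shown sit.

The compounds shown leave open how far compound 2 and compound 3 actually lie from each other, and whether the change on the oxygen has any effect at all in this assay. They also leave open what an amine or a carboxylic acid would do in place of the methoxy group, and whether a longer chain in place of the ethyl group of compound 3 would bring the read-out back to a measured number.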